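Removing the Ester Chain from a Hydrazone Series

The compounds below may be only part of what the source reports. "The series", "measured", "known", "first", "only" and "open" are said of these compounds alone.

Compound 1 `C/C(=N\Nc1nc(-c2ccc(Br)cc2)cs1)c1cc2ccccc2o1`: 32700 nM
Compound 2 `C/C(=N\Nc1nc(-c2ccc(Cl)cc2)cs1)c1cc2ccccc2o1`: 26600 nM
Compound 3 `CCOC(=O)Cc1csc(N/N=C(\C)c2cc3ccccc3o2)n1`: 9260 nM

These three compounds were tested in a functional assay on HeLa cells (Homo sapiens) for antiproliferative activity; a higher number here means a weaker inhibitor, a lower number a stronger inhibitor. Compound 3 gives the lowest number of the three: the step is a 2.9-fold lower number from compound 2 to compound 3 (0.46 log units; beyond the scatter) and a 3.5-fold lower number from compound 1 to compound 3 (0.55 log units; beyond the scatter). Compound 4 `C/C(=N\Nc1nc(C)cs1)c1cc2ccccc2o1` is not yet measured. It differs from compound 3 by hydrogen in place of ethoxycarbonyl on a saturated chain carbon bound to an aromatic carbon. For the measured compounds named here, no measured step removes this group; the two steps that reached compound 3 exchanged a 4-bromophenyl or 4-chlorophenyl group for the (ethoxycarbonyl)methyl chain, each a modest gain, so what the ethoxycarbonyl part alone contributes is unknown. A step of about a 1.7-fold higher number from compound 3 to compound 4 (0.24 log units; within the scatter) is therefore expected, with wide uncertainty in either direction. Compound 4 is expected to give 16000 nM in this assay, within 5000 nM to 50000 nM.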

Compound 4, half-maximal inhibitory concentration: 8970 nM
Beside the measured number, compound 4's estimate is 1.8-fold (0.25 log units) above it, and the stated range covers the measured number.
By their numbers in this assay, from the lowest: compounds 4 and 3 (each within the scatter of the next); then compounds 2 and 1 (each within the scatter of the next).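

In this assay the step for cutting (ethoxycarbonyl)methyl back to methyl is a 1.0-fold lower number from compound 3 to compound 4 (0.01 log units; within the scatter) and so the ethoxycarbonyl part is not needed to hold this level of activity. The plain methyl alone also keeps the modest edge over the aryl compounds, with a 3.0-fold lower number from compound 2 to compound 4 (0.47 log units; beyond the scatter) and a 3.6-fold lower number from compound 1 to compound 4 (0.56 log units; beyond the scatter) as its steps. Nothing measured here explains this.

Going by these compounds, it remains open whether a carboxylic acid, an amine or a longer chain on that saturated chain carbon would shift the number in either direction.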